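Dimethylphenyl in place of difluorophenyl on the amide nitrogen

This account rests on a few compounds, and the source may have more. Where it says the series, first, only, none or still open, it means among the compounds named here.

Compound 3 `O=C(CN1CCC(c2cccc[n+]2[O-])CC1)Nc1ccc(F)cc1F` was tested in a functional assay on HEK293 cells for agonist activity at D(4) dopamine receptor (Homo sapiens), read by FLIPR (on this read-out higher numbers stand for an effect only at larger amounts of compound and lower numbers for an effect already at smaller amounts), and gave 103 nM. Among the three numbers so far, that of compound 3 stands second highest, yet compound 1 `C=Cc1cccc(C(=O)NCN2CCC(c3cccc[n+]3[O-])CC2)c1` gives 68 nM and compound 2 `Cc1cccc(NC(=O)CN2CCC(c3ccccc3)CC2)c1` gives 170 nM, and both lie within the scatter of the value of compound 3. Among the measured compounds shown here, no pair of measured compounds differs in a single place, so the effect of a change on the amide nitrogen has not been measured here. Compound 4 `Cc1cccc(C)c1NC(=O)CN1CCC(c2cccc[n+]2[O-])CC1` carries the change (2,6-dimethylphenyl in place of 2,4-difluorophenyl on an amide-type nitrogen). For the measured compounds named here, with no measured step of this kind, the expected step of a 1.1-fold higher number from compound 3 to compound 4 (0.03 log units; within the scatter) is none beyond the scatter. Compound 4 is therefore estimated at 110 nM, with a range from 50 nM to 250 nM.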

Compound 4, half-maximal effective concentration: 346 nM
Estimate against measurement, compound 4: 3.1-fold (0.50 log units) below; measured number above the stated range.
By their numbers in this assay, from the lowest: compounds 1, 3 and 2 (each within the scatter of the next, the first and the last beyond it); then compound 4.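

Among the compounds shown here, replacing 2,4-difluorophenyl with 2,6-dimethylphenyl on the amide-type nitrogen gives the first single-place step here: in this assay there is a 3.4-fold higher number from compound 3 to compound 4 (0.53 log units; beyond the scatter), so the group at this position can shift the number beyond the scatter. The two groups match in heavy-atom count and in hydrogen-bond donors and acceptors, so those counts do not separate them. Nothing available explains the rise. Going by these compounds, it remains open whether a 2,6-difluorophenyl or a 2,4-dimethylphenyl would stand with compound 3 or compound 4, and so whether the kind of substituent or its place on the ring carries the step.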